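Adding one methoxy to compound 1: expected cytotoxicity

The source may hold more compounds than are shown below. What is called first, only, known or untested is meant among the compounds shown, and "the series" means these compounds.

Measured in a functional assay on SW-620 cells (Homo sapiens) for cytotoxicity, read by MTT assay, with a stated time of 72 h (a higher number here means a weaker inhibitor, a lower number a stronger inhibitor), so far:
Compound 1 `COc1cccc(/C=C2\CCC/C(=C\c3cccc(OC)c3OC)C2=O)c1` gives 7000 nM
Compound 2 `COc1cccc(/C=C2\CCC/C(=C\c3cccc(Cl)c3Cl)C2=O)c1OC` gives 16300 nM

Compound 1 holds the lower of the two numbers. Compound 3 `COc1cc(/C=C2\CCC/C(=C\c3cccc(OC)c3OC)C2=O)cc(OC)c1` is still unmeasured and differs from compound 1 by one change: methoxy in place of hydrogen on an aromatic carbon with methoxy in place of hydrogen on an aromatic carbon. Among the measured compounds shown here, the only measured step is a 2.3-fold higher number from compound 1 to compound 2 (0.37 log units; beyond the scatter) and it replaces 3-methoxyphenyl with 2,3-dichlorophenyl. For the measured compounds named here, that modest step is a different exchange, and no measured step adds a methoxy, so it bears only loosely on this change. No shift beyond the scatter is expected in this assay and the data give no firm direction. Compound 3 is estimated at 6000 nM with an expected range of 2500 nM to 15000 nM for repeat measurements. The estimate means an expected step of a 1.2-fold lower number from compound 1 to compound 3 (0.07 log units; within the scatter) in this series.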

Compound 3, half-maximal inhibitory concentration: 3800 nM
Compound 3: the middle estimate sits 1.6-fold (0.20 log units) above what was measured, and the stated range covers the measured number.
By their numbers in this assay, from the lowest: compounds 3 and 1 (each within the scatter of the next); then compound 2.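

In this assay the addition of methoxy in place of hydrogen, on an aromatic carbon meta to a large group and meta to a methoxy group, gives a 1.8-fold lower number from compound 1 to compound 3 (0.27 log units; within the scatter) and so sets no order between the two compounds. Unlike the earlier exchange of a whole aryl group, this step isolates a single aromatic position, and the added methoxy there produces no shift beyond the scatter. No measurement on hand accounts for the size of this step.

Going by these compounds, it remains open whether this position tolerates groups other than methoxy, such as a hydroxy, an amine or a carboxylic acid on the same aromatic carbon. On these data alone, the effect of a longer chain, such as ethoxy, in place of the added methoxy also remains open.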